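Aryl amine variation in the antiproliferative series

The source may hold more compounds than are shown below. What is called first, only, known or untested is meant among the compounds shown, and "the series" means these compounds.

Compound 1 `CNC(=O)c1ccccc1Oc1nc(Nc2ccccc2OC)ncc1Br` sits at the edge of a functional assay on MCF7 cells (Homo sapiens) for antiproliferative activity, read by MTT assay, with a stated time of 24 h; on this read-out lower numbers stand for stronger inhibition and higher numbers for weaker inhibition: in this assay compound 1 gives > 50000 nM, a limit rather than a number (the limit of > 50000 nM in this assay, at which 1 of the 2 values shown sits). Compound 2 `CNC(=O)c1ccccc1Oc1nc(Nc2cccc(C)c2)ncc1Br` gives 16600 nM in this assay, and the step reads an at least 3.0-fold lower number from compound 1 to compound 2 (0.47 log units; beyond the scatter). Compound 3 `CNC(=O)c1ccccc1Oc1nc(Nc2cccc(C(C)C)c2)ncc1Br` differs from compound 1 by 3-isopropylphenyl in place of 2-methoxyphenyl on a nitrogen on an aromatic ring. Among the measured compounds shown here, the only measured step bearing on this change is the one from compound 1 to compound 2, which lowered the number beyond the scatter. A step of similar direction and size is expected here, an at least 3.3-fold lower number from compound 1 to compound 3 (0.52 log units; beyond the scatter). Compound 3 is estimated at 15000 nM, within 5000 nM to 50000 nM.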

Compound 3, half-maximal inhibitory concentration: 26500 nM
Estimate against measurement, compound 3: 1.8-fold (0.25 log units) below; the range from low to high includes it.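

Compound 1 stands at a limit, not a number: the limit of > 50000 nM in this assay, at which 1 of the 3 values shown sits. In this assay the change gives an at least 1.8-fold lower number from compound 1 to compound 3 (0.27 log units; that floor lies within the scatter), so the floor for 3-isopropylphenyl in place of 2-methoxyphenyl on the nitrogen does not clear the scatter, as the floor for 3-methylphenyl did. The exchange on the aromatic carbon gives a 1.6-fold higher number from compound 2 to compound 3 (0.20 log units; within the scatter), so isopropyl and methyl are not told apart here.

As far as these compounds go, whether an amine or a carboxylic acid in place of isopropyl on that aromatic carbon would give a number clearly apart from compound 2 stays open.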